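The source may hold more compounds than are shown below. What is called first, only, known or untested is meant among the compounds shown, and "the series" means these compounds.

Measured so far in a functional assay on HT cells (Homo sapiens) for antiproliferative activity, read by fluorescence, with a stated time of 72 h; a lower number here means a stronger inhibitor of growth, a higher number a weaker inhibitor of growth:
- compound 1 `CCC(O)CSc1nc(NCc2ccc(-c3ccccn3)cc2)c2[nH]nc(C(C)C)c2n1`: 273 nM
- compound 2 `CC(C)c1n[nH]c2c(NCc3ccc(-c4ccccn4)cc3)nc(SC[C@H](O)CN)nc12`: 63 nM
- compound 3 `CC(C)c1n[nH]c2c(NCc3ccc(-c4ccccn4)cc3)nc(SC3CCCC3O)nc12`: 567 nM

Compound 2 holds the lowest number of the three in this assay. The move a 4.3-fold lower number from compound 1 to compound 2 (0.64 log units; beyond the scatter) and the move a 9.0-fold higher number from compound 2 to compound 3 (0.95 log units; beyond the scatter) both set it apart, and the move a 2.1-fold higher number from compound 1 to compound 3 (0.32 log units; beyond the scatter) places compound 3 at the high end.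

Compound 4 `CC(C)c1n[nH]c2c(NCc3ccc(-c4ccccn4)cc3)nc(S)nc12` differs from compound 2 in one place: hydrogen in place of 3-amino-2-hydroxypropyl on a sulfur. The two steps that bear on this are the ones touching compound 2. Putting the amine into the side chain lowered the number, as a 4.3-fold lower number from compound 1 to compound 2 (0.64 log units; beyond the scatter) shows, and exchanging the amino-hydroxy chain for a hydroxycyclopentyl raised it, as a 9.0-fold higher number from compound 2 to compound 3 (0.95 log units; beyond the scatter) shows. Compound 4 keeps neither the amine nor the hydroxyl, so a step upward beyond the scatter is expected, likely at least as large as the loss seen on the way to compound 3. The estimated step is a 14-fold higher number from compound 2 to compound 4 (1.15 log units; beyond the scatter). For compound 4 a value of 900 nM is expected, in the range 250 nM to 3500 nM.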

Compound 4, concentration for 50% growth inhibition: 2760 nM
Beside the measured number, compound 4's estimate is 3.1-fold (0.49 log units) below it; low and high end bracket the measured number.
By their numbers in this assay, from the lowest: compound 2; then compound 1; then compound 3; then compound 4.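

In this assay, taking the whole group off the sulfur raises the number from every substituted compound: a 44-fold higher number from compound 2 to compound 4 (1.64 log units; beyond the scatter), a 10-fold higher number from compound 1 to compound 4 (1.00 log units; beyond the scatter) and a 4.9-fold higher number from compound 3 to compound 4 (0.69 log units; beyond the scatter). The free sulfanyl compound therefore ranks above all three, so even the 2-hydroxycyclopentyl group, the highest of the earlier set, carries a lower number than hydrogen, and the largest step belongs to the 3-amino-2-hydroxypropyl chain. No measurement among the data accounts for the size of these steps.

Still open, from the compounds shown here alone, is whether a plain methyl or a longer alkyl chain, with neither hydroxyl nor amine, on this sulfur would already give most of the drop from the sulfanyl compound. Also open, going by these compounds, is whether a 2-aminoethyl chain, with the amine but no hydroxyl, would match the 3-amino-2-hydroxypropyl chain.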